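Imidazolylpropyl for dimethylaminopropyl on the shared core

The source may report more compounds than this note shows. Statements on the series, on what has been measured and on what is new or still open speak of the compounds shown alone.

The series is read in a functional assay on KB cells (Homo sapiens) for antiproliferative activity, read by MTT assay, with a stated time of 48 h; a lower number here means a stronger inhibitor, a higher number a weaker inhibitor. Compound 1, `CN(C)CCCn1nc(C2=C(c3cn(C)c4ccccc34)C(=O)NC2=O)c2cccnc21`, stands only at a limit of the assay: in this assay compound 1 gives > 100000 nM, a limit and not a number. Compound 2, `Cn1cc(C2=C(c3nn(CCCn4cccc4)c4ncccc34)C(=O)N(c3ccccc3)C2=O)c2ccccc21`, gives > 100000 nM in this assay, again a limit. Compound 3, `Cn1cc(C2=C(c3nn(CCCN4CCCCC4)c4ncccc34)C(=O)N(c3ccc(Cl)cc3)C2=O)c2ccccc21`, gives > 100000 nM in this assay, also a limit. For the measured compounds named here, all three values sit at the limit of > 100000 nM in this assay, at which 3 of the 3 values shown sit, so no ordering among compound 1, compound 2 and compound 3 can be read from them, and no step between any two of them is known.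

Compound 4, `Cn1cc(C2=C(c3nn(CCCn4ccnc4)c4ncccc34)C(=O)NC2=O)c2ccccc21`, keeps the unsubstituted imide of compound 1 and differs from it only in the chain: 1H-imidazol-1-yl in place of dimethylamino on a saturated chain carbon, three bonds along the chain from an aromatic nitrogen. Going by the values given here, no measured step accompanies this change. Given that compound 1 sits at the limit > 100000 nM, the expected step that the limit leaves unreadable from compound 1 to compound 4 is none beyond the scatter, with the most likely outcome that compound 4 is also reported only as a limit. Compound 4 is expected to give 150000 nM in this assay, estimated between 30000 nM and 600000 nM.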

Compound 4, half-maximal inhibitory concentration: > 100000 nM
Compound 4 ended at the assay's limit; the forecaster's own chance of this, stated with the estimate: 75%; the middle value is on the limit's open side.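

The step from compound 1 to compound 4 cannot be read, since both values are limits and not numbers: the limit of > 100000 nM in this assay, at which 4 of the 4 values shown sit.

The compounds shown leave open whether 1H-imidazol-1-yl in place of dimethylamino changes activity at all, and which change to the shared core or its chain would give a value short of that limit.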